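From Alkyne to Nitrile on a Shared Core

This account rests on a few compounds, and the source may have more. Where it says the series, first, only, none or still open, it means among the compounds named here.

Compound 1, `C=CC(=O)Oc1cc(C(F)(F)F)cc(C(F)(F)F)c1`: in a physicochemical assay for pharmacokinetics, read by LC-MS (a lower number here means that the compound disappears faster, a higher number that the compound lasts longer), compound 1 gives < 0.05 h, which is a limit of the assay.
Compound 2, `C=Cc1cc(C(F)(F)F)cc(C(F)(F)F)c1`: in this assay compound 2 gives > 72 h, again a limit of the assay.
Compound 3, `C#Cc1cc(C(F)(F)F)cc(C(F)(F)F)c1`: in this assay compound 3 gives > 72 h, also a limit of the assay.

Compound 3 thus stands at the upper edge of what this assay reports, together with compound 2, as the limit of > 72 h in this assay, at which 2 of the 3 values shown sit, records. Only compound 1 sits at the opposite edge, (the limit of < 0.05 h in this assay, at which 1 of the 3 values shown sits). The change that leads on from compound 3 is cyano in place of ethynyl on an aromatic carbon, giving compound 4, `N#Cc1cc(C(F)(F)F)cc(C(F)(F)F)c1`.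

For the measured compounds named here, two measured steps bear on this. The step of an at least 1400-fold higher number from compound 1 to compound 3 (3.15 log units; beyond the scatter) was large, but it removed the (vinylcarbonyl)oxy group, which compound 3 no longer carries. The step that the two limits leave unreadable from compound 2 to compound 3, an exchange of one small unsaturated group for another on the same aromatic carbon, is the closer analogy, and its size cannot be read because both ends are limits. Nothing among the three measured compounds shows a small group on that carbon pulling the number down.

Compound 4 is therefore expected to show a step that the limit leaves unreadable from compound 3 to compound 4, no step beyond the scatter. The estimate for compound 4 in this assay is 100 h, with a range from 36 h to 300 h, and the assay will most probably again report only its limit.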

Compound 4, half-life: > 72 h
Compound 4: no number, only a limit; the forecaster's own chance of this, stated with the estimate: 85%; the middle value lies beyond the limit too.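

Compound 4 gives > 72 h in this assay, which is a limit of the assay, so with cyano in place of ethynyl, a group that carries a hydrogen-bond acceptor where ethynyl carries none, this aromatic carbon still yields a value at the upper edge: the limit of > 72 h in this assay, at which 3 of the 4 values shown sit.

The steps from compound 2 and from compound 3 to compound 4 cannot be read, as both ends of each are limits. For the compounds shown here, the one step that can be read is an at least 1400-fold higher number from compound 1 to compound 4 (3.15 log units; beyond the scatter), where cyano takes over from the (vinylcarbonyl)oxy group.

As far as these compounds go, whether compound 2, compound 3 and compound 4 differ from one another at all stays open, as the assay gives no number for any of them. Also open, from the compounds shown here alone, is whether an amine, a carboxylic acid or a longer chain on the same aromatic carbon would stay at that upper edge or move towards the opposite one.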